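Difluoronitrophenyl series: removing the benzyl ester group

The source may hold more compounds than are shown below. What is called first, only, known or untested is meant among the compounds shown, and "the series" means these compounds.

- compound 1 `COC(=O)c1ccc(CN(CCCc2c(N)nc(N)nc2O)c2cc(F)cc(F)c2[N+](=O)[O-])cc1`: > 100000 nM
- compound 2 `COC(=O)c1ccc(CN(CCCc2c(N)nc(N)nc2O)c2cc(F)c(F)cc2[N+](=O)[O-])cc1`: 59000 nM
- compound 3 `COC(=O)c1ccc(CN(CCCc2c(N)nc(N)nc2O)c2ccc([N+](=O)[O-])c(F)c2F)cc1`: 41000 nM

All three compounds were tested in a functional assay on CCRF-CEM cells (Homo sapiens) for cytotoxicity, in the absence of a further agent; a lower number here means a stronger inhibitor, a higher number a weaker inhibitor. For compound 1, the entry is a limit and not a number. In this assay compound 3 gives 41000 nM, within the scatter of compound 2 at 59000 nM. Those two compounds are separated by a 1.4-fold lower number from compound 2 to compound 3 (0.16 log units; within the scatter), while the largest measured change is an at least 2.4-fold lower number from compound 1 to compound 3 (0.38 log units; beyond the scatter).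

The next compound is compound 4 `Nc1nc(N)c(CCCNc2ccc([N+](=O)[O-])c(F)c2F)c(O)n1`, which has hydrogen in place of 4-(methoxycarbonyl)benzyl on a nitrogen on an aromatic ring. The measured steps only exchange one difluoronitrophenyl pattern for another, and none removes this group, so they give little guidance on size or direction. The expectation therefore starts from compound 3 at 41000 nM, and only a small rise is assumed. The expected change is a 1.5-fold higher number from compound 3 to compound 4 (0.17 log units; within the scatter), with a real chance of a limit result. The estimate for compound 4 is 60000 nM, with an expected range of 15000 nM to 150000 nM.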

Compound 4, half-maximal inhibitory concentration: 76000 nM
Beside the measured number, compound 4's estimate is 1.3-fold (0.10 log units) below it; the range from low to high includes it.
By their numbers in this assay, from the lowest: compounds 3, 2 and 4 (each within the scatter of the next). At a limit, above all of these: compound 1.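

In this assay, hydrogen in place of 4-(methoxycarbonyl)benzyl on the nitrogen gives a 1.9-fold higher number from compound 3 to compound 4 (0.27 log units; within the scatter). Among the compounds shown here, the earlier steps only exchanged one difluoronitrophenyl pattern for another, so this is the first reading at this position, and loss of all 11 heavy atoms of the group produces no change beyond the scatter. Compound 1 remains a limit and not a number, so the series sits close to the top of what this read-out can report, leaving little room to see a further loss: the limit of > 100000 nM in this assay, at which 1 of the 4 values shown sits.

On these data alone, whether a carboxylic acid in place of the methyl ester, or a plain benzyl or methyl group on this nitrogen, would move the number beyond the scatter remains open. Also open, as far as these compounds go, is whether hydrogen on this nitrogen gives a similar result with the other two difluoronitrophenyl patterns.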